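Thiophene in place of dimethylphenyl on the enone chain

The source may hold more compounds than are shown below. What is called first, only, known or untested is meant among the compounds shown, and "the series" means these compounds.

Measured so far in a functional assay on DU-145 cells (Homo sapiens) for inhibition, read by trypan blue exclusion, with a stated time of 96 h; a higher number here means a weaker inhibitor of growth, a lower number a stronger inhibitor of growth:
compound 1 `Cc1ccc(/C=C(\C(=O)c2ccc(Cl)cc2)S(=O)(=O)Cc2ccc(Cl)cc2)s1` gives 1000 nM
compound 2 `Cc1ccc(C)c(/C=C(\C(=O)c2ccc(Cl)cc2)S(=O)(=O)Cc2ccc(Cl)cc2)c1` gives 10000 nM
compound 3 `Cc1cc(C)cc(/C=C(\C(=O)c2ccc(Cl)cc2)S(=O)(=O)Cc2ccc(Cl)cc2)c1` gives 1000 nM

Compound 3 stands level with compound 1 at the digits printed, and the two together give the lowest numbers of the three; its nearest neighbour is compound 1, with no change at the digits printed from compound 1 to compound 3 (within the scatter) read in reverse, and its furthest is compound 2, with a 10-fold lower number from compound 2 to compound 3 (1.00 log units; beyond the scatter).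

The next compound is compound 4 `Cc1ccsc1/C=C(\C(=O)c1ccc(Cl)cc1)S(=O)(=O)Cc1ccc(Cl)cc1`. Its change from compound 3 is 3-methylthiophen-2-yl in place of 3,5-dimethylphenyl on a double-bonded chain carbon bound to a double-bonded chain carbon.

For the measured compounds named here, two measured steps bear on this. Exchanging a five-membered ring with one sulfur for a six-membered carbon ring gave no change at the digits printed from compound 1 to compound 3 (within the scatter), so the ring type as such changed nothing beyond the scatter. Moving methyl groups on the six-membered ring, however, gave a 10-fold lower number from compound 2 to compound 3 (1.00 log units; beyond the scatter), so the methyl pattern can shift the number by a modest amount. Going by the values given here, compound 4 returns to a thiophene ring, as in compound 1, but with the methyl in a different position than in compound 1; no measured pair shows that exact shift on a thiophene.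

The expected step is therefore a 2.0-fold higher number from compound 3 to compound 4 (0.30 log units; within the scatter), small and leaning toward a higher number. The estimate for compound 4 is 2000 nM, within 600 nM to 8000 nM.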

Compound 4, concentration for 50% growth inhibition: 25000 nM
Compound 4: the middle estimate sits 13-fold (1.10 log units) below what was measured; measured number above the stated range.
By their numbers in this assay, from the lowest: compounds 1 and 3 (each within the scatter of the next); then compound 2; then compound 4.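

In this assay, the thiophene ring does not act as a single unit at this place, on a double-bonded chain carbon bound to a double-bonded chain carbon: moving the methyl from 5-methylthiophen-2-yl to 3-methylthiophen-2-yl gives a 25-fold higher number from compound 1 to compound 4 (1.40 log units; beyond the scatter), so ring type alone does not set the number. The 3-methylthiophen-2-yl group also stands apart from both dimethylphenyl groups, with a 25-fold higher number from compound 3 to compound 4 (1.40 log units; beyond the scatter) and a 2.5-fold higher number from compound 2 to compound 4 (0.40 log units; beyond the scatter), which leaves compound 4 with the highest number of the four. Across these compounds, the two higher numbers belong to 2,5-dimethylphenyl and 3-methylthiophen-2-yl, and the two lower numbers to 5-methylthiophen-2-yl and 3,5-dimethylphenyl, so methyl placement separates the series more clearly than the choice of ring does, with no compound here against that reading.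

Nothing available accounts for the size of these steps. As far as these compounds go, it remains open whether an unsubstituted thiophen-2-yl, or an ethyl or methoxy group in place of the methyl on the thiophene, would sit with compound 1 or with compound 4.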